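Benzyl ester in place of oxo-amide on the shared core

The source may hold more compounds than are shown below. What is called first, only, known or untested is meant among the compounds shown, and "the series" means these compounds.

Working notes on the series. In a functional assay on HEL cells (Homo sapiens) for cytotoxicity, read by microscopy (on this read-out higher numbers stand for lower toxicity in this test and lower numbers for higher toxicity in this test), compound 1 `Cc1cn([C@@H]2O[C@H](CO[Si](C)(C)C(C)(C)C)[C@@]3(OS(=O)(=O)C=C3NCCC(=O)O)[C@H]2O[Si](C)(C)C(C)(C)C)c(=O)n(C)c1=O` gives 80000 nM. Compound 2 `Cc1cn([C@@H]2O[C@H](CO[Si](C)(C)C(C)(C)C)[C@@]3(OS(=O)(=O)C=C3NCC(=O)C(N)=O)[C@H]2O[Si](C)(C)C(C)(C)C)c(=O)n(C)c1=O` gives only a limit of >= 16000 nM in this assay, so for compound 2 no number is available, only that limit. The step that the limit leaves unreadable from compound 1 to compound 2 cannot be read for size, and the limit of >= 16000 nM in this assay, at which 1 of the 2 values shown sits, is all the pair shows.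

Compound 3 `Cc1cn([C@@H]2O[C@H](CO[Si](C)(C)C(C)(C)C)[C@@]3(OS(=O)(=O)C=C3NCC(=O)OCc3ccccc3)[C@H]2O[Si](C)(C)C(C)(C)C)c(=O)n(C)c1=O` differs from compound 2 by benzyloxy in place of carbamoyl on a carbonyl carbon. Among the measured compounds shown here, no readable measured step bears on this change; the only step measured is a step that the limit leaves unreadable from compound 1 to compound 2, which the limit hides. Compound 1 and compound 2 both sit in the weakly cytotoxic region, and compound 3 is expected to remain there as well, with an estimated step that the limit leaves unreadable from compound 2 to compound 3 that is not expected to go beyond the scatter. For compound 3 the expected value in this assay is 40000 nM, in the range 10000 nM to 100000 nM.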

Compound 3, minimum cytotoxic concentration: >= 400000 nM
Compound 3 was reported as a limit; the forecaster's own chance of this, stated with the estimate: 60%; middle value at least 10-fold (1.00 log units) from the limit.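

In this assay, among the compounds shown here, benzyloxycarbonyl in place of carboxymethyl on a saturated chain carbon bound to an amine nitrogen gives an at least 5.0-fold higher number from compound 1 to compound 3 (0.69 log units; beyond the scatter), the only readable step so far. From the compounds shown here alone, compound 3 is reported only as a limit, >= 400000 nM, and not as a number, so the true size of this step remains unknown. Compound 2 is also only a limit, >= 16000 nM, so the steps that run through it cannot be read, and benzyloxy in place of carbamoyl on a carbonyl carbon has no size of its own.

The compounds shown leave open whether the step from compound 1 goes with the aromatic ring of the benzyloxy group or with the ester itself, a question that a methyl ester at the same place would address. Going by these compounds, how a longer chain carrying the benzyl ester would read in this assay also stays open.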